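The source may hold more compounds than are shown below. What is called first, only, known or untested is meant among the compounds shown, and "the series" means these compounds.

The study concerns inhibition read on a single cell line at one concentration. Compound 1 `CCNc1nccc2c1ncn2C1O[C@H](CO)[C@@H](O)[C@H]1O` was tested in a functional assay on EL4 cells (Mus musculus) for inhibition, tested at 100 uM (on this read-out lower numbers stand for less inhibition and higher numbers for more inhibition at the one concentration tested (going by the name of the read-out)), where compound 1 gives 8%. For the measured compounds named here, that figure is the only full number among the measured compounds; the second measured compound yields only a limit. Compound 2 `OC[C@H]1O[C@@H](n2cnc3c(S)nccc32)C[C@@H]1O` is reported in this assay as a limit, < 5%, not as a number. Where compound 1 stands is therefore judged against (the limit of < 5% in this assay, at which 1 of the 2 values shown sits), and its own reading lies close to that boundary. Going by the values given here, no pair of measured compounds differs in a single place, so no measured step is available to calibrate how much a change of this kind moves the read-out.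

The unmeasured compound 3 `[N-]=[N+]=Nc1nccc2c1ncn2C1O[C@H](CO)[C@@H](O)[C@H]1O` relates to compound 1 through one change: azido in place of ethylamino on an aromatic carbon. The ethylamino leaves and an azido enters on the same aromatic carbon of the six-membered ring with one nitrogen, within the fused two-ring system. Among the compounds with values here, with compound 1 already near the bottom of the scale and no measured step to suggest a shift, the expected step from compound 1 to compound 3 is estimated as a number 1 percentage points lower from compound 1 to compound 3 (within the scatter), which is none beyond the scatter. Compound 3 is therefore expected to give about 7% in this assay, within a range of 0% to 18%.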

Compound 3, a percentage reported as inhibition, at one concentration (the size of the read-out at that concentration, not a potency): < 5%
Compound 3: only a limit was reported; the forecaster's own chance of this, stated with the estimate: 35%; middle value at least 2 percentage points from the limit.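

Compound 3 is reported in this assay only as a limit, < 5%, not as a number. For the compounds shown here, this gives the first single change that can be read at this position, on an aromatic carbon next to the ring nitrogen: azido in place of ethylamino gives a number at least 3 percentage points lower from compound 1 to compound 3 (that floor lies within the scatter), so the change brings no rise in inhibition out of the scatter, and a group with no carbon and no hydrogen-bond donor leaves the reading at the foot of the scale just as the ethylamino does. With the shared core unchanged, the reading now sits at the floor for two of the three compounds, which means that the scale offers little room to tell these groups apart at the one concentration tested: the limit of < 5% in this assay, at which 2 of the 3 values shown sit.

The compounds shown leave open whether any group on this aromatic carbon can produce clear inhibition in this assay, for instance a plain amine or a longer chain such as butylamino. From the compounds shown here alone, how far compound 3 truly lies from compound 1 also stays unknown, as a limit gives no exact size for the step.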